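Adding a nitro group to compound 1

The source may report more compounds than this note shows. Statements on the series, on what has been measured and on what is new or still open speak of the compounds shown alone.

Compound 1 `O=C(CCCCC(S)CCS)Nc1ccccc1` is the starting point. In a functional assay on HO8910 cells (Homo sapiens) for inhibition, read by MTT assay, with a stated time of 24 h, tested at 1 ug/mL (a higher number here means more inhibition of growth at the concentration tested, a lower number less inhibition of growth), compound 1 gives 6.38%, and its two measured relatives both stay within the scatter of it, so it has no clear place above or below them. Each relative replaces a single hydrogen on an aromatic carbon. Compound 2 `O=C(CCCCC(S)CCS)Nc1ccccc1Cl`, which carries chloro, gives 7.72%. That step is a number 1.3 percentage points higher from compound 1 to compound 2 (within the scatter). Compound 3 `O=C(CCCCC(S)CCS)Nc1cccc(C(F)(F)F)c1`, which carries trifluoromethyl, gives 13.7%. That step is a number 7.3 percentage points higher from compound 1 to compound 3 (within the scatter).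

Compound 4 `O=C(CCCCC(S)CCS)Nc1ccc([N+](=O)[O-])cc1` has not yet been measured. Its change from compound 1 is nitro in place of hydrogen on an aromatic carbon, para to a large group: nitro in place of hydrogen on an aromatic carbon. Neither measured step brings in nitro, so the two steps offer only a rough guide. Still, both are swaps of the same general kind, and both were small. The step expected in this assay is therefore also small and in the upward direction of those two, an estimated a number 4.6 percentage points higher from compound 1 to compound 4 (within the scatter), with no change beyond the scatter expected. For compound 4 the estimated value is 11%, with an expected range from 3% to 22%.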

Compound 4, percent growth inhibition at one concentration: 0.76%
Compound 4: middle estimate off by 10.2 percentage points, on the high side, outside the stated range (below it).
By their numbers in this assay, from the lowest: compounds 4, 1, 2 and 3 (each within the scatter of the next, the first and the last beyond it).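

In this assay the nitro step is a number 5.6 percentage points lower from compound 1 to compound 4 (within the scatter) and, like the chloro and trifluoromethyl steps, it does not rise above the usual spread of repeated measurements. This adds a new kind of group at a new place, on an aromatic carbon para to a large group, with nitrogen and oxygen atoms and hydrogen-bond acceptors entering where only a hydrogen stood. Even so, the single nitro swap produces no clear change in growth inhibition at this concentration, and although this step points the opposite way from the two earlier ones, a step of this size cannot establish a real difference in direction. Nothing further in the data bears on this result.

Going by these compounds, it remains open whether any group at this place can move the read-out beyond the scatter, for example an amine or a carboxylic acid on the same aromatic carbon. Because each compound is shown at only one concentration, it also remains open how these compounds would compare at other concentrations.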